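The source may hold more compounds than are shown below. What is called first, only, known or untested is meant among the compounds shown, and "the series" means these compounds.

Two amides on the shared core have been measured. Compound 1, `COc1ccc(C(=O)Nc2ccccc2Cl)cc1OC1CCCC1`, gives 190 nM in an assay on isolated protein for inhibition of phosphodiesterase 4A (Sus scrofa); a higher number here means a weaker inhibitor, a lower number a stronger inhibitor. Compound 2, `COc1ccc(C(=O)Nc2ccccc2C(F)(F)F)cc1OC1CCCC1`, gives 3100 nM in the same assay. Among the compounds with values here, the one step available, a 16-fold higher number from compound 1 to compound 2 (1.21 log units; beyond the scatter), is the only guide to what a group on this position of the aniline ring does. On the numbers shown, compound 2 stands highest of the two, and its nearest neighbour is compound 1, a large step away.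

Compound 3, `COc1ccc(C(=O)Nc2ccccc2C(=O)c2ccccc2)cc1OC1CCCC1`, has not been measured. It differs from compound 2 in one place: benzoyl in place of trifluoromethyl on an aromatic carbon. The step from compound 1 to compound 2 bears on it only loosely, since it concerned a change at the same position but with a different entering group; that step was large and toward weaker inhibition. Within the data shown here, no measured step tells what a benzoyl does here, so the expectation is wide. A further step toward weaker inhibition is expected, a 1.6-fold higher number from compound 2 to compound 3 (0.21 log units; within the scatter), but a return toward compound 1 cannot be ruled out. Compound 3 is therefore expected to give about 5000 nM in this assay, within 1000 nM to 30000 nM.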

Compound 3, half-maximal inhibitory concentration: 1700 nM
Compound 3: the middle estimate sits 2.9-fold (0.47 log units) above what was measured, and the stated range covers the measured number.
By their numbers in this assay, from the lowest: compound 1; then compounds 3 and 2 (each within the scatter of the next).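

In this assay the change to benzoyl gives a 1.8-fold lower number from compound 2 to compound 3 (0.26 log units; within the scatter), so a group of 8 heavy atoms with a six-membered aromatic ring and a hydrogen-bond acceptor cannot be told apart from trifluoromethyl, a group of 4 heavy atoms with no ring and no acceptor, at this position. Chloro remains the one group that separates from the others, with an 8.9-fold higher number from compound 1 to compound 3 (0.95 log units; beyond the scatter) alongside the larger step already seen for trifluoromethyl, which leaves compound 1 the strongest of the three and compounds 2 and 3 together on the weaker side. No measurement at hand accounts for this order or for the similar readings of two such different groups.

The compounds shown leave open whether chloro is the best group tried here only because so few have been compared, and whether a plain hydrogen, a fluorine or a methyl at this position would match compound 1 or pass it. They also leave open how a benzyl, an amine or a carboxylic acid would read here, and so whether the tolerance shared by trifluoromethyl and benzoyl extends to other groups.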